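The source may hold more compounds than are shown below. What is called first, only, known or untested is meant among the compounds shown, and "the series" means these compounds.

Measured compounds in an assay on HEK293 cells for agonist activity at transient receptor potential cation channel subfamily M member 8 (Homo sapiens), read by fluorescence and calcium flux, with a stated time of 15 min; on this read-out higher numbers stand for an effect only at larger amounts of compound and lower numbers for an effect already at smaller amounts:
- compound 1 `CCN(Cc1ccc(C)s1)C(=O)COc1ccc(C)cc1` gives 178 nM
- compound 2 `Cc1ccc(OCC(=O)N(CCCO)Cc2cccs2)cc1` gives 3000 nM
- compound 3 `CCN(Cc1ccsc1)C(=O)COc1ccc(C)cc1` gives 88 nM

Compound 2 stands at the highest number of the three in this assay: next to it is compound 1 with a markedly lower number, and furthest from it is compound 3. Compound 4 `Cc1ccc(OCC(=O)N(Cc2cccs2)C(C)C)cc1` is not yet measured. It differs from compound 2 in one place: isopropyl in place of 3-hydroxypropyl on an amide-type nitrogen. Among the measured steps, only a 2.0-fold lower number from compound 1 to compound 3 (0.31 log units; beyond the scatter) exists, and it concerns the ring on the chain carbon, not the group on the amide-type nitrogen, so it does not bear on this change. What can be said is that compound 1 and compound 3 both carry ethyl on that nitrogen and give far lower numbers than compound 2 with its 3-hydroxypropyl. A small saturated group without donor or acceptor, as in isopropyl, is therefore expected to move compound 4 toward those numbers, giving an estimated 15-fold lower number from compound 2 to compound 4 (1.18 log units; beyond the scatter). Compound 4 is estimated at 200 nM, with a range from 60 nM to 700 nM.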

Compound 4, half-maximal effective concentration: 70 nM
Beside the measured number, compound 4's estimate is 2.9-fold (0.46 log units) above it; measured number inside the range.
By their numbers in this assay, from the lowest: compounds 4 and 3 (each within the scatter of the next); then compound 1; then compound 2.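

Among the compounds shown here, with isopropyl in place of 3-hydroxypropyl on an amide-type nitrogen, this assay shows a 43-fold lower number from compound 2 to compound 4 (1.63 log units; beyond the scatter) and so gives the first reading of a change at this position alone. For the compounds shown here, this large step exceeds a 2.0-fold lower number from compound 1 to compound 3 (0.31 log units; beyond the scatter), the only earlier single-place step, which concerns the ring on the chain carbon. The change replaces a group carrying a hydrogen-bond donor and acceptor with one carrying neither, but no measurement here accounts for the step.

The compounds shown do not separate the loss of the hydroxyl from the change of chain shape, which a straight propyl or a 3-methoxypropyl group on the same nitrogen could address. Going by these compounds, how an amine or a carboxylic acid at the end of the chain would read also stays open.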